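The source may hold more compounds than are shown below. What is called first, only, known or untested is meant among the compounds shown, and "the series" means these compounds.

Working notes on the series. Compound 1 `CCC(C)C1NC(=O)N(C2CCCCC2)C1=O` is the reference point here. In a functional assay on MIA PaCa-2 cells (Homo sapiens) for inhibition (on this read-out lower numbers stand for stronger inhibition and higher numbers for weaker inhibition), compound 1 gives > 100000 nM, and this is a limit of the assay rather than a number. Where compound 1 stands on the numbers shown is therefore fixed only by the limit of > 100000 nM in this assay, at which 1 of the 2 values shown sits. Compound 2 `CCC(C)C(NC(=O)n1nnc2ccccc21)C(=O)NC1CCCCC1` is the other measured member. In this assay compound 2 gives 40200 nM, a measured number. For the measured compounds named here, the two values together show that neither compound is a strong inhibitor; no step between them is worked out here, so nothing more is drawn from the pair.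

Compound 3 `CC(C)C1NC(=O)N(C2CCCCC2)C1=O` differs from compound 1 by hydrogen in place of methyl on a saturated chain carbon, two bonds along the chain from a saturated ring carbon; read one bond further out, ethyl becomes methyl and sec-butyl becomes isopropyl. Going by the values given here, no measured step of this size exists. In this assay such a change is expected to shift the read-out by no more than the usual scatter, with no clear direction. Compound 3 is therefore expected at 150000 nM, within a range of 50000 nM to 500000 nM. The expected step is a step that the limit leaves unreadable from compound 1 to compound 3, with a limit again the most probable outcome.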

Compound 3, half-maximal inhibitory concentration: > 100000 nM
Compound 3 was reported as a limit; the forecaster's own chance of this, stated with the estimate: 85%; the middle value is on the limit's open side.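

Compound 3 gives > 100000 nM, which is a limit and not a number. No step from compound 1 to compound 3 can be read, because compound 1 also stands at a limit: the limit of > 100000 nM in this assay, at which 2 of the 3 values shown sit.

The compounds shown leave open whether hydrogen in place of methyl on this saturated chain carbon changes the read-out at all.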